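A few compounds are considered here, and "the series" means these few. Any claim that something is new, unique, unknown or untested is made for them only; others in the source may bear on it.

Working notes on the series. In a functional assay on UO-31 cells (Homo sapiens) for inhibition (on this read-out higher numbers stand for weaker inhibition of growth and lower numbers for stronger inhibition of growth), compound 1 `O=C(/C=C/c1cccc(O)c1)c1cccc(-n2cc(-c3ccccc3)[nH]c2=O)c1` gives 2160 nM, compound 2 `O=C(/C=C/c1cccc(O)c1)c1cccc(-n2cc(-c3ccc(Cl)cc3)[nH]c2=O)c1` gives 550 nM and compound 3 `COc1ccc(-c2cn(-c3cccc(C(=O)/C=C/c4cc(OC)c(OC)c(OC)c4)c3)c(=O)[nH]2)cc1` gives 1910 nM. Compound 2 stands lowest of the three numbers. For the measured compounds named here, the only single-point step measured so far is a 3.9-fold lower number from compound 1 to compound 2 (0.59 log units; beyond the scatter). Compound 4 `COc1cc(/C=C/C(=O)c2cccc(-n3cc(-c4ccc(Cl)cc4)[nH]c3=O)c2)ccc1O` differs from compound 2 by 4-hydroxy-3-methoxyphenyl in place of 3-hydroxyphenyl on a double-bonded chain carbon bound to a double-bonded chain carbon. Going by the values given here, no measured step touches that ring alone: compound 1 and compound 3 differ there and also at the other aryl group, and their two values lie within the scatter of each other, which is all they show. For compound 4 no step beyond the scatter in this assay is therefore expected, a 1.2-fold higher number from compound 2 to compound 4 (0.07 log units; within the scatter). Compound 4 is estimated at 650 nM, with a range from 250 nM to 1700 nM.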

Compound 4, concentration for 50% growth inhibition: 1670 nM
Compound 4: the middle estimate sits 2.6-fold (0.41 log units) below what was measured; the measured number falls inside the stated range.
By their numbers in this assay, from the lowest: compound 2; then compounds 4, 3 and 1 (each within the scatter of the next).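

In this assay, for the compounds shown here, the ring on the double-bonded chain carbon proves able to shift the read-out: 4-hydroxy-3-methoxyphenyl in place of 3-hydroxyphenyl gives a 3.0-fold higher number from compound 2 to compound 4 (0.48 log units; beyond the scatter) and is the first step read at this ring alone. The step holds for the 4-chlorophenyl-bearing core of compound 2 only. Nothing on hand accounts for it.

Going by these compounds, the change combines an added methoxy group with a different hydroxy placement, so which part carries the step stays open. Also open, on these data alone, is how plain 4-hydroxyphenyl or a ring bearing a dimethylamino group would read here.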